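The source may report more compounds than this note shows. Statements on the series, on what has been measured and on what is new or still open speak of the compounds shown alone.

In a functional assay on HeLa cells (Homo sapiens) for antiproliferative activity, read by spectrophotometry, with a stated time of 2 days (on this read-out higher numbers stand for weaker inhibition of growth and lower numbers for stronger inhibition of growth), compound 2 `COc1cc(Nc2ncc(C(F)(F)F)c(N3Cc4cccc(N(C)S(C)(=O)=O)c4C3)n2)c(OC)cc1Cl` gives 16500 nM as its concentration for half-maximal growth inhibition. Compound 3 `CN(c1cccc2c1CN(c1nc(Nc3cc(C(F)(F)F)cc(C(F)(F)F)c3)ncc1C(F)(F)F)C2)S(C)(=O)=O` gives 9200 nM and lies within the usual scatter of compound 2. Compound 1 `CC(=O)N1CCN(c2ccc(Nc3ncc(C(F)(F)F)c(N4Cc5cccc(N(C)S(C)(=O)=O)c5C4)n3)cc2)CC1` gives 730 nM and lies lower than compound 2 by well beyond the scatter. Compound 2 therefore stands at the weak end of these three numbers, level with compound 3.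

The next case is compound 4 `CN(c1cccc2c1CN(c1nc(Nc3ccc(Cl)c(C(F)(F)F)c3)ncc1C(F)(F)F)C2)S(C)(=O)=O` with 4-chloro-3-(trifluoromethyl)phenyl in place of 4-chloro-2,5-dimethoxyphenyl on a nitrogen on an aromatic ring and the shared core unchanged. Within the data shown here, no measured pair shows this exchange on its own. Compound 3 at 9200 nM also carries trifluoromethyl on that ring, so its number serves as the nearest guide. The estimated shift a 1.8-fold lower number from compound 2 to compound 4 (0.26 log units; within the scatter) points toward stronger inhibition of growth in this assay but stays within the scatter, so no real step is expected. Compound 4 is expected near 9000 nM with a likely range from 3000 nM to 20000 nM in this estimate.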

Compound 4, concentration for 50% growth inhibition: 11100 nM
Beside the measured number, compound 4's estimate is 1.2-fold (0.09 log units) below it; measured number inside the range.
By their numbers in this assay, from the lowest: compound 1; then compounds 3, 4 and 2 (each within the scatter of the next).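

In this assay, among these compounds, putting 4-chloro-3-(trifluoromethyl)phenyl in place of 4-chloro-2,5-dimethoxyphenyl gives a 1.5-fold lower number from compound 2 to compound 4 (0.17 log units; within the scatter), which is the first reading of a single change at this place, on a nitrogen on an aromatic ring. Among the compounds shown here, the entering group has 0 hydrogen-bond acceptors where the leaving group has 2, with the same count of heavy atoms, yet in this one pair that exchange brings no real step in growth inhibition. No measurement at hand says why the two groups read alike.

The compounds shown leave open whether a carboxylic acid or a nitrile on this phenyl ring would shift the number beyond the scatter. They also leave open whether this exchange would read the same on a different core.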